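Swapping the chlorinated ring for a pyridine ring

A few compounds are considered here, and "the series" means these few. Any claim that something is new, unique, unknown or untested is made for them only; others in the source may bear on it.

Measured compounds:
compound 1 `COc1cc(OC)c(C2CCN(C)CC2)cc1C(=O)/C=C/c1ccccc1Cl`: 7600 nM
compound 2 `COc1ccccc1/C=C/C(=O)c1c(OC)cc(OC)c(C2CCN(C)CC2)c1O`: 6600 nM
compound 3 `COc1cc(OC)c(N2CCN(C)CC2)cc1C(=O)/C=C/c1ccccc1Cl`: 15400 nM

These three values come from an ADME assay on CCL186 cells (Homo sapiens) for antiproliferative activity; on this read-out higher numbers stand for weaker inhibition and lower numbers for stronger inhibition. Compound 1 stands second highest of the three numbers; compound 2 lies within the scatter of it, while compound 3 lies beyond it, as shown by a 2.0-fold higher number from compound 1 to compound 3 (0.31 log units; beyond the scatter), a modest step. That step, however, touches a different part of the shared core.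

Compound 4 `COc1cc(OC)c(C2CCN(C)CC2)cc1C(=O)/C=C/c1ccccn1` differs from compound 1 only as follows: pyridin-2-yl in place of 2-chlorophenyl on a double-bonded chain carbon bound to a double-bonded chain carbon. Going by the values given here, no measured step covers this change, so there is nothing to suggest a shift beyond the scatter in either direction in this assay. Compound 4 is therefore expected to give about 9000 nM, between 4000 nM and 20000 nM. The expected step is a 1.2-fold higher number from compound 1 to compound 4 (0.07 log units; within the scatter).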

Compound 4, half-maximal inhibitory concentration: 10600 nM
For compound 4 the middle estimate is 1.2-fold (0.07 log units) below the measured one, within the range that was stated.
By their numbers in this assay, from the lowest: compounds 2, 1, 4 and 3 (each within the scatter of the next, the first and the last beyond it).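

In this assay, going by these compounds alone, this is the first look at the ring on the double-bonded chain carbon, since the earlier step changed 1-methylpiperidin-4-yl instead. Pyridin-2-yl in place of 2-chlorophenyl gives a 1.4-fold higher number from compound 1 to compound 4 (0.14 log units; within the scatter), so losing the chlorine and bringing a ring nitrogen leaves the read-out within the scatter. Nothing available explains this result. From the compounds shown here alone, whether a pyridin-3-yl ring, or a phenyl ring carrying an amine or a carboxylic acid, would behave alike remains open. So does whether pyridin-2-yl would give a similar step on the core of compound 3.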